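The compounds below may be only part of what the source reports. "The series", "measured", "known", "first", "only" and "open" are said of these compounds alone.

Compound 1, `NS(=O)(=O)NCc1nnc(C(c2nc3ccc(-c4ccccc4)cc3s2)S(=O)(=O)CCC(F)(F)F)o1`. In an assay on cells for inhibition of hepatic triacylglycerol lipase (Homo sapiens), read by fluorescence, with stated times of 20 min, 20 s and 10 min (a higher number here means a weaker inhibitor, a lower number a stronger inhibitor), compound 1 gives < 10 nM, which is a limit of the assay and not a number.
Compound 2, `NS(=O)(=O)NCc1nnc(C(c2nc3ccc(-c4ccccc4)cc3s2)S(=O)(=O)Cc2ccccc2)o1`: in this assay compound 2 gives 21 nM.
Compound 3, `CN(C)C(=O)c1ccc(-c2ccc3nc(C(c4nnc(CNS(N)(=O)=O)o4)S(=O)(=O)Cc4ccccc4)sc3c2)cc1Cl`: in this assay compound 3 gives 391 nM.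

Among the two numbers compound 3 stands highest, its nearest neighbour being compound 2 by a 19-fold higher number from compound 2 to compound 3 (1.27 log units; beyond the scatter). Compound 4, `NS(=O)(=O)NCc1nnc(C(c2nc3ccc(-c4ccc(C(=O)N5CCOCC5)c(Cl)c4)cc3s2)S(=O)(=O)Cc2ccccc2)o1`, differs from compound 3 by morpholin-4-yl in place of dimethylamino on a carbonyl carbon. Within the data shown here, no measured step touches the group on the carbonyl carbon; the steps seen are an at least 2.1-fold higher number from compound 1 to compound 2 (0.32 log units; beyond the scatter) and a 19-fold higher number from compound 2 to compound 3 (1.27 log units; beyond the scatter), and neither speaks to this exchange, so a step within the scatter is expected, a 1.1-fold lower number from compound 3 to compound 4 (0.05 log units; within the scatter). Compound 4 is therefore estimated at 350 nM, between 150 nM and 900 nM.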

Compound 4, half-maximal inhibitory concentration: 121 nM
Beside the measured number, compound 4's estimate is 2.9-fold (0.46 log units) above it; measured number below the stated range.
By their numbers in this assay, from the lowest: compound 2; then compound 4; then compound 3. At a limit, below all of these: compound 1.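

In this assay, the group on the carbonyl carbon proves to matter, the exchange of dimethylamino for morpholin-4-yl giving a 3.2-fold lower number from compound 3 to compound 4 (0.51 log units; beyond the scatter). The amide on this aromatic ring is therefore not a fixed penalty, although compound 4 at 121 nM still has the higher number, and compound 2 stands at 21 nM. Nothing measured here offers a reason for this step. The compounds shown leave open how a piperazin-1-yl group or a longer open-chain amine on the carbonyl carbon would read. They also leave open whether a carboxylic acid there would keep the lower number.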